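Trifluoromethyl placement in the furan-2-ylmethyl compounds

The compounds below may be only part of what the source reports. "The series", "measured", "known", "first", "only" and "open" are said of these compounds alone.

Measured in a functional assay on HepG2 cells (Homo sapiens) for cytotoxicity, read by MTT assay, with a stated time of 48 h; a lower number here means a stronger inhibitor, a higher number a weaker inhibitor:
- compound 1 `O=C(CSc1ccc([N+](=O)[O-])cc1)N1N=C(c2cc3ccccc3oc2=O)C[C@@H]1c1ccccc1C(F)(F)F`: 7700 nM
- compound 2 `O=C(CSCc1ccco1)N1N=C(c2cc3ccccc3oc2=O)C[C@@H]1c1ccccc1C(F)(F)F`: 18000 nM

Of these two numbers, compound 2 has the higher at 18000 nM, making it the weaker inhibitor of the pair. Compound 3 `O=C(CSCc1ccco1)N1N=C(c2cc3ccccc3oc2=O)C[C@@H]1c1ccc(C(F)(F)F)cc1` keeps the sulfur side chain of compound 2 and carries 4-(trifluoromethyl)phenyl in place of 2-(trifluoromethyl)phenyl on a saturated ring carbon of the five-membered non-aromatic ring: 4-(trifluoromethyl)phenyl in place of 2-(trifluoromethyl)phenyl on a saturated ring carbon.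

Among the measured compounds shown here, the only measured step is a 2.3-fold higher number from compound 1 to compound 2 (0.37 log units; beyond the scatter). It is modest and comes from (furan-2-yl)methyl replacing 4-nitrophenyl on a sulfur, a change at another place in the molecule. For the measured compounds named here, no measured step alters the trifluoromethyl-bearing aryl group, so the data give no direction for this change. That step serves only as a rough scale, and no step beyond the scatter is expected in this assay. The estimate is a 1.2-fold lower number from compound 2 to compound 3 (0.08 log units; within the scatter), with only weak support from two measured compounds. For compound 3 the expected value is 15000 nM, with an estimated range of 6000 nM to 35000 nM.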

Compound 3, half-maximal inhibitory concentration: 11200 nM
For compound 3 the middle estimate is 1.3-fold (0.13 log units) above the measured one; the measured number falls inside the stated range.
By their numbers in this assay, from the lowest: compounds 1, 3 and 2 (each within the scatter of the next, the first and the last beyond it).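

In this assay, 4-(trifluoromethyl)phenyl in place of 2-(trifluoromethyl)phenyl on the saturated ring carbon gives a 1.6-fold lower number from compound 2 to compound 3 (0.21 log units; within the scatter). Among the compounds shown here, this is the first reading at this position: with the ((furan-2-yl)methyl)sulfanyl side chain held fixed, the two trifluoromethyl placements on the phenyl group cannot be told apart in this assay, so the placement has no resolved effect on the number here. No data bear on why the two compounds read as they do.

As far as these compounds go, it remains open whether the two placements would also match with the 4-nitrophenyl group of compound 1 on the sulfur, since this single pair rests on one side chain and cannot be extended to the series. Also open, from the compounds shown here alone, is how far the number at this ring carbon can move at all, which a plain phenyl with no trifluoromethyl, or a phenyl bearing a carboxylic acid or an amine, would begin to show.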